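Extending the Acid of Compound 3 into an Ester Chain

This account rests on a few compounds, and the source may have more. Where it says the series, first, only, none or still open, it means among the compounds named here.

Compound 3 `O=C(O)c1ccc(-c2nn(Cc3ccccc3)c3ccccc23)cc1` stands at a position known only as a limit. In a functional assay on cells (Platelet, Homo sapiens) for inhibition (a lower number here means a stronger inhibitor, a higher number a weaker inhibitor), compound 3 gives > 10000 nM, which is a limit of the assay and not a number. Compound 1 `CCOC(=O)c1ccc(-c2nn(Cc3cccc(Cl)c3)c3ccccc23)cc1` also gives > 10000 nM in this assay, again a limit. Compound 2 `CCOC(=O)c1ccc(-c2nn(C(C)C)c3ccccc23)cc1` gives > 10000 nM in this assay, once more a limit. Among the compounds with values here, the single step between measured neighbours, a step that the two limits leave unreadable from compound 1 to compound 2, is therefore unreadable, and the limit of > 10000 nM in this assay, at which 3 of the 3 values shown sit, sums up the whole picture. Compound 4 `CCOC(=O)/C=C/c1ccc(-c2nn(Cc3ccccc3)c3ccccc23)cc1` differs from compound 3 by 2-(ethoxycarbonyl)ethenyl in place of carboxy on an aromatic carbon. Within the data shown here, no measured step bears directly on this change, and nothing in the data points away from the limit. Compound 4 is therefore expected to give about 15000 nM in this assay, within 3000 nM to 60000 nM, most likely reported as a limit again. The step that the limit leaves unreadable from compound 3 to compound 4 is expected to be none beyond the scatter.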

Compound 4, half-maximal inhibitory concentration: > 10000 nM
Compound 4 gave a limit, no number; the forecaster's own chance of this, stated with the estimate: 75%; the middle value is on the limit's open side.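

No step can be read between compound 3 and compound 4, since each gives only a limit, and the evidence stays the same: the limit of > 10000 nM in this assay, at which 4 of the 4 values shown sit.

The compounds shown leave open which structural change, if any, would give a measurable value in this assay.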